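The compounds below may be only part of what the source reports. "The series", "measured", "known", "first", "only" and "open" are said of these compounds alone.

Working notes on the series. Three compounds have so far been run in an ADME assay on CHO cells (Cricetulus griseus) for inhibition, read by MTT assay; a lower number here means a stronger inhibitor, a higher number a weaker inhibitor. Going by the values given here, compound 1 `CCN(CC)Cc1ccc(Nc2nc3ccccc3n2Cc2ccc(F)cc2)cc1O` gives 45800 nM in this assay and is the only member of the set with a numerical result. Compound 2 `CCN(CC)Cc1c(Cl)ccc(Nc2nc3ccccc3n2Cc2ccc(C(F)(F)F)cc2)c1O` returns > 50000 nM, which is a limit of the assay and not a number. Compound 3 `CCNCc1cc(Cl)cc(Nc2nc3cc(F)c(F)cc3[nH]2)c1O` returns > 50000 nM, again a limit. Two of the three readings thus sit at the limit of > 50000 nM in this assay, at which 2 of the 3 values shown sit, and compound 1 stands alone with a value just short of that limit. Among the compounds with values here, no two measured compounds differ in a single place, so no step can be read from the measured set.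

Compound 4 `CCN(CC)Cc1ccc(Nc2nc3ccccc3n2Cc2ccc(C(F)(F)F)cc2)cc1O` is not yet measured. It differs from compound 1 by trifluoromethyl in place of fluoro on an aromatic carbon. Compound 2 also carries a 4-(trifluoromethyl)benzyl and gave only a limit, but it differs from compound 4 in more than one place, so only the bare readings of that pair can be compared. No step beyond the usual scatter is expected in this assay, and a limit rather than a number is a real possibility. Compound 4 is estimated at 60000 nM, with a range of 25000 nM to 150000 nM. The expected step is a 1.3-fold higher number from compound 1 to compound 4 (0.12 log units; within the scatter), essentially no change beyond the scatter.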

Compound 4, half-maximal inhibitory concentration: 41500 nM
Beside the measured number, compound 4's estimate is 1.4-fold (0.16 log units) above it, and the stated range covers the measured number.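

Replacing fluoro with trifluoromethyl on this aromatic carbon, para to a large group, gives a 1.1-fold lower number from compound 1 to compound 4 (0.04 log units; within the scatter) in this assay. Going by these compounds alone, this is the first step that can be read, and it shows that going from 4-fluorobenzyl to 4-(trifluoromethyl)benzyl, with one heavy atom leaving and four entering, keeps the reading within the scatter, so compound 1 and compound 4 cannot be ranked. Compound 4, like compound 1, returns a number and not a limit, so on this core neither group takes the reading to the limit of the assay, a finding that rests on this single pair.

As far as these compounds go, whether the reading stays this flat with a group of another kind at this carbon, such as an amine, a carboxylic acid or a plain hydrogen, remains open, as does whether the change would behave alike on the cores of compound 2 and compound 3. Steps to those two compounds cannot be read, since each differs from the others in more than one place and gives only a limit: the limit of > 50000 nM in this assay, at which 2 of the 4 values shown sit.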